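The source may hold more compounds than are shown below. What is called first, only, known or untested is meant among the compounds shown, and "the series" means these compounds.

Compound 3, whose structure is `COc1cc(C)[nH]c(=O)c1CN1CCc2c(Cl)cc([C@@H](O)C3COC3)c(Cl)c2C1=O`, is the weakest of the three compounds measured here: in a functional assay on KARPAS-422 cells (Homo sapiens) for antiproliferative activity, read by resazurin assay, with a stated time of 72 h (a higher number here means a weaker inhibitor, a lower number a stronger inhibitor), compound 3 gives 10600 nM. Its nearest neighbour on the numbers is compound 1, `Cc1cc(C)c(CN2CCc3c(Cl)cc([C@@H](C)CO)c(Cl)c3C2=O)c(=O)[nH]1`, which in this assay gives 1500 nM; furthest away stands compound 2, `Cc1cc(C)c(CN2CCc3c(Cl)cc(-c4c(C)noc4C)c(Cl)c3C2=O)c(=O)[nH]1`, which gives 23 nM. Among the compounds with values here, the one measured step, a 65-fold lower number from compound 1 to compound 2 (1.81 log units; beyond the scatter), exchanges one ring substituent for another and says nothing about stereochemistry.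

Compound 4, `COc1cc(C)[nH]c(=O)c1CN1CCc2c(Cl)cc([C@H](O)C3COC3)c(Cl)c2C1=O`, differs from compound 3 only in configuration: the two compounds have the same atoms and bonds and differ only in configuration as drawn: 1 of 1 stereo elements differ; a stereocentre at a saturated chain carbon is drawn S in compound 3 and R in compound 4. No measured pair among these compounds bears directly on such a change, so the size and direction of the step cannot be read from the data. Compound 3 is so weak that the inverted centre of compound 4 could in principle be the one that carries activity, but there is equally no evidence to exclude a step within the scatter in either direction. Balancing these, the account expects compound 4 to come out modestly stronger, a step of a 2.7-fold lower number from compound 3 to compound 4 (0.42 log units; beyond the scatter). The estimate for compound 4 in this assay is therefore 4000 nM, with a range from 500 nM to 20000 nM.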

Compound 4, half-maximal inhibitory concentration: 108 nM
The estimate for compound 4 lay 37-fold (1.57 log units) above the measured number; measured number outside the range, below it.
By their numbers in this assay, from the lowest: compound 2; then compound 4; then compound 1; then compound 3.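

In this assay, inverting the single stereocentre at the saturated chain carbon, from S to R, gives a 98-fold lower number from compound 3 to compound 4 (1.99 log units; beyond the scatter), so at this position the configuration as drawn is by itself enough to produce a large change in the number. The earlier compounds shown here showed a large step only for the exchange of one group for another, a 65-fold lower number from compound 1 to compound 2 (1.81 log units; beyond the scatter), and gave no sign that a change leaving every atom and bond in place could also be large. The step can be assigned to this one stereocentre alone, because nothing else separates the pair: the fact that compounds 3 and 4 differ only in the configuration as drawn

The compounds shown leave open whether the stereocentre in the 1-(hydroxymethyl)ethyl group of compound 1 responds to inversion in the same way, as only one configuration of that group stands here. They also leave open whether the hydroxyl group on the stereocentre of compound 4 is needed for the stronger number, or whether an amine or a methoxy group at that carbon would give a similar result.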